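A few compounds are considered here, and "the series" means these few. Any claim that something is new, unique, unknown or untested is made for them only; others in the source may bear on it.

Values in a functional assay on HepG2 cells (Homo sapiens) for antiproliferative activity, read by CCK-8 assay, with a stated time of 72 h; a lower number here means a stronger inhibitor, a higher number a weaker inhibitor:
- Compound 1 `O=C(/C=C/c1ccc(CN2CCc3ccccc32)cc1)NO`: 14900 nM
- Compound 2 `Nc1ccccc1NC(=O)c1ccc(COc2ccc(Cl)cc2)cc1`: > 32000 nM (a limit)
- Compound 3 `Nc1ccccc1NC(=O)/C=C/c1ccc(COc2ccccc2)cc1`: > 32000 nM (a limit)

Only compound 1 has a measured number. Compound 2 has no number, only the limit > 32000 nM, and compound 3 shares this position at the limit of > 32000 nM in this assay, at which 2 of the 3 values shown sit.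

Compound 4 `CC(C)c1ccc(OCc2ccc(C(=O)Nc3ccccc3N)cc2)cc1` is still to be measured. It differs from compound 2 at one place: isopropyl in place of chloro on an aromatic carbon. This puts isopropyl in place of chloro on an aromatic carbon, para to a large group.

Among the compounds with values here, no measured step bears on this change, so the expected a number no higher from compound 2 to compound 4 (the limit leaves the size open) is none beyond the scatter, and another limit would not surprise. For compound 4 the estimated value is 32000 nM, with an expected range of 14000 nM to 70000 nM.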

Compound 4, half-maximal inhibitory concentration: > 32000 nM
Compound 4: only a limit was reported (the forecaster's own chance of this, stated with the estimate: 65%); the middle value sits exactly at the limit.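

No step can be read from compound 2 to compound 4, since both carry only a limit in this assay: the limit of > 32000 nM in this assay, at which 3 of the 4 values shown sit.

The compounds shown leave open whether isopropyl in place of chloro changes the result in this assay at all.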